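Metabolic Stability After a Change on the Carbonyl Carbon

A few compounds are considered here, and "the series" means these few. Any claim that something is new, unique, unknown or untested is made for them only; others in the source may bear on it.

Compound 1, `O=C(NCc1ccc(S(=O)(=O)c2cc(F)cc(F)c2)cc1)c1cc2ccncc2o1`: 77%
Compound 2, `O=C(NCc1ccc(S(=O)(=O)N2CCCCC2)cc1)c1ccn2cncc2c1`: 54%
Compound 3, `O=C(NCc1ccc(S(=O)(=O)c2ccccc2)cc1)c1ccc2ccncc2c1`: 46%

In an ADME assay on microsomes from liver (Homo sapiens) for metabolic stability, read by LC-MS, with a stated time of 30 min, tested at 1 uM (a lower number here means that less of the compound is left, a higher number that more of the compound is left), compound 1 gives 77%, the highest of the three numbers; compound 2 gives 54%, lower by a margin beyond the scatter, and compound 3 gives 46%, further below still. Compound 4, `O=C(NCc1ccc(S(=O)(=O)c2cc(F)cc(F)c2)cc1)c1cc2cnccc2[nH]1`, has not yet been measured. It differs from compound 1 in one place: a group of 9 heavy atoms (7 carbon, 2 nitrogen; one five-membered aromatic ring with 1 hetero atom, one six-membered aromatic ring with 1 hetero atom) in place of a group of 9 heavy atoms (7 carbon, 1 nitrogen, 1 oxygen; one five-membered aromatic ring with 1 hetero atom, one six-membered aromatic ring with 1 hetero atom), on a carbonyl carbon. Going by the values given here, no measured pair shows the effect of such a change, so there is no step to lean on. The change is expected to cost little or nothing beyond the scatter, and the step of a number 11 percentage points lower from compound 1 to compound 4 (beyond the scatter) is the estimate of it. For compound 4 the expected value is 66%, in a range from 45% to 85%.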

Compound 4, percent of the compound remaining: 82%
Compound 4: the middle estimate sits 16 percentage points below what was measured, within the range that was stated.
By their numbers in this assay, from the lowest: compounds 3 and 2 (each within the scatter of the next); then compounds 1 and 4 (each within the scatter of the next).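

On the carbonyl carbon, the group with 1 hydrogen-bond donor and 1 hydrogen-bond acceptor can replace the group with 0 hydrogen-bond donors and 2 hydrogen-bond acceptors with no change beyond the scatter in this assay (a number 5 percentage points higher from compound 1 to compound 4 (within the scatter)). Among the compounds shown, this is the only pair that differs in one place, so this position now has a measured step. Nothing available explains why the two groups give such similar numbers. Still open, as far as these compounds go, is how a plain phenyl ring on the carbonyl carbon would compare in this assay. Also open, from the compounds shown here alone, is whether this swap gives a similar step in compounds with a different sulfonyl group from that of compound 1.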